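The source may hold more compounds than are shown below. What is called first, only, known or untested is meant among the compounds shown, and "the series" means these compounds.

Three compounds share a core in which a carbamate-bearing chain ends in a diketo amide, and all three have been tested in an assay on isolated protein for binding affinity to cathepsin L2 (Homo sapiens), read by fluorescence; a higher number here means a weaker inhibitor, a lower number a stronger inhibitor. Compound 1 `CCCC[C@H](NC(=O)O[C@H](Cc1nnc(-c2ccccc2)o1)C(C)(C)C)C(=O)C(=O)N[C@H](C)c1ccccc1` gives 1600 nM. Among the compounds with values here, compound 2 `CCCC[C@H](NC(=O)O[C@H](Cc1nnc(-c2ccccc2)o1)C(C)C)C(=O)C(=O)N[C@H](C)c1ccccc1` gives 5600 nM, and the one step between them, a 3.5-fold higher number from compound 1 to compound 2 (0.54 log units; beyond the scatter), concerns the carbamate side only. Compound 3 `CCCC[C@H](NC(=O)O[C@H](Cn1ccc(-c2ccc(C(F)(F)F)cc2)n1)C(C)(C)C)C(=O)C(=O)Nc1ccccn1` gives 4500 nM in this assay; among the three numbers it stands second highest, within the scatter of compound 2 and beyond the scatter of compound 1.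

Compound 4 `CCCC[C@H](NC(=O)O[C@H](Cn1ccc(-c2ccc(C(F)(F)F)cc2)n1)C(C)(C)C)C(=O)C(=O)NCc1ccno1` differs from compound 3 in one place: (1,2-oxazol-5-yl)methyl in place of pyridin-2-yl on an amide-type nitrogen. Within the data shown here, the only measured step, from compound 1 to compound 2, touches a different part of the molecule, so no measured step bears on this change, and nothing here shows how this assay responds to it. With no guide, the expectation is a step of no clear direction, most likely within the scatter, so no change at the digits printed from compound 3 to compound 4 (within the scatter) is the estimate. Compound 4 is therefore expected to give about 4500 nM, with a range from 1500 nM to 14000 nM.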

Compound 4, half-maximal inhibitory concentration: 36000 nM
Estimate against measurement, compound 4: 8.0-fold (0.90 log units) below; the whole stated range lies below it.
By their numbers in this assay, from the lowest: compound 1; then compounds 3 and 2 (each within the scatter of the next); then compound 4.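

In this assay, putting (1,2-oxazol-5-yl)methyl in place of pyridin-2-yl on the amide-type nitrogen brings an 8.0-fold higher number from compound 3 to compound 4 (0.90 log units; beyond the scatter) and makes compound 4 the weaker inhibitor. This shows that the assay responds to what sits on this nitrogen, a part of the molecule the earlier step on the carbamate side did not touch. The two groups have the same number of heavy atoms, yet they differ in ring type, hetero atoms and hydrogen-bond acceptors, and nothing shown gives a reason for the loss.

Which part of the change matters stays open, since the ring and the link to the nitrogen change together. A (pyridin-2-yl)methyl group or a 1,2-oxazol-5-yl group on this nitrogen would pull those two apart.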